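The compounds below may be only part of what the source reports. "The series", "measured", "known", "first", "only" and "open" are said of these compounds alone.

compound 1 `C=CC(=O)N1C(=O)CC(c2ccc(OC)cc2)Sc2ccccc21`: 92100 nM
compound 2 `C=CC(=O)N1C(=O)CC(c2ccccc2Cl)Sc2ccccc21`: 91400 nM
compound 3 `C=CC(=O)N1C(=O)CC(c2cccc(Cl)c2)Sc2ccccc21`: 93100 nM

In a functional assay on HL-60 cells (Homo sapiens) for cytotoxicity, read by CCK-8 assay, with a stated time of 24 h (a higher number here means a weaker inhibitor, a lower number a stronger inhibitor), compound 1 gives 92100 nM and cannot be separated from the other two compounds. Replacing 4-methoxyphenyl with 2-chlorophenyl gives a 1.0-fold lower number from compound 1 to compound 2 (0.00 log units; within the scatter). Replacing it with 3-chlorophenyl gives a 1.0-fold higher number from compound 1 to compound 3 (0.00 log units; within the scatter). Moving between the two chlorophenyl groups gives a 1.0-fold higher number from compound 2 to compound 3 (0.01 log units; within the scatter).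

The next compound is compound 4 `C=CC(=O)N1C(=O)CC(c2ccc(C(=O)OC)cc2)Sc2ccccc21`, with methoxycarbonyl in place of methoxy on an aromatic carbon, para to a large group: methoxycarbonyl in place of methoxy on an aromatic carbon. Among the measured compounds shown here, the three steps above are the only evidence that bears on this change, and none of them leaves the scatter. For the measured compounds named here, no measured compound carries methoxycarbonyl, so this substituent is untested in this assay and the expectation is loose. No step beyond the scatter is expected, in either direction. The expected step is a 1.0-fold lower number from compound 1 to compound 4 (0.02 log units; within the scatter). The estimated value for compound 4 is 88000 nM, with an expected range from 45000 nM to 140000 nM.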

Compound 4, half-maximal inhibitory concentration: 102000 nM
Compound 4: the middle estimate sits 1.2-fold (0.06 log units) below what was measured, and the stated range covers the measured number.
By their numbers in this assay, from the lowest: compounds 2, 1, 3 and 4 (each within the scatter of the next).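

In this assay, methoxycarbonyl in place of methoxy on an aromatic carbon, para to a large group, gives a 1.1-fold higher number from compound 1 to compound 4 (0.04 log units; within the scatter), so compound 4 cannot be separated from compound 1. The earlier steps shown here changed only methoxy and chloro substituents; this one shows that a group with 4 heavy atoms, 2 hydrogen-bond acceptors and a double bond outside aromatic rings, replacing one with 2 heavy atoms and 1 hydrogen-bond acceptor, also stays within the scatter. No evidence on any property of these compounds bears on this result.

Going by these compounds, whether a carboxylic acid or an amine at this place would leave the scatter remains open. The compounds shown also share the acryloyl group, so what replacing it with a saturated propanoyl group would do is equally unknown.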